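Working notes: amide substituent changes and antiproliferative readout

The source may hold more compounds than are shown below. What is called first, only, known or untested is meant among the compounds shown, and "the series" means these compounds.

Measured so far in a functional assay on BXPC-3 cells (Homo sapiens) for antiproliferative activity, read by MTT assay, with a stated time of 24 h; a higher number here means a weaker inhibitor, a lower number a stronger inhibitor:
compound 1, `CCn1c(C(=O)NC(C)(C)CO)ccc1C(CC)(CC)c1ccc(OCS(=O)(=O)c2ccccc2)c(C)c1`: 18300 nM
compound 2, `CCn1c(C(=O)NC2(CO)CC2)ccc1C(CC)(CC)c1ccc(OCS(=O)(=O)c2ccccc2)c(C)c1`: 45400 nM
compound 3, `CCn1c(C(=O)N[C@H](CO)C(C)C)ccc1C(CC)(CC)c1ccc(OCS(=O)(=O)c2ccccc2)c(C)c1`: 7720 nM

Compound 3 gives the lowest number of the three in this assay. The steps to it are both beyond the scatter: a 2.4-fold lower number from compound 1 to compound 3 (0.37 log units; beyond the scatter), and a 5.9-fold lower number from compound 2 to compound 3 (0.77 log units; beyond the scatter). Between the other two, a 2.5-fold higher number from compound 1 to compound 2 (0.39 log units; beyond the scatter). All three measured steps change the carbon framework of the group on the amide-type nitrogen while the hydroxymethyl is kept in every case.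

Compound 4, `CCn1c(C(=O)N[C@H](C(=O)O)C(C)C)ccc1C(CC)(CC)c1ccc(OCS(=O)(=O)c2ccccc2)c(C)c1`, differs from compound 3 as follows: carboxy in place of hydroxymethyl on a saturated chain carbon bound to an amide-type nitrogen and a saturated chain carbon. Within the data shown here, no measured step touches the hydroxymethyl itself, so none bears directly on this change; the measured steps only show that alterations at this group produce modest shifts in this assay. The direction for compound 4 is therefore not anchored by a measured analogue. As a working expectation, compound 4 is estimated at a 1.9-fold higher number from compound 3 to compound 4 (0.29 log units; within the scatter), with wide uncertainty. The estimated value for compound 4 is 15000 nM, within an expected range of 4000 nM to 60000 nM.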

Compound 4, half-maximal inhibitory concentration: 16200 nM
Compound 4: the middle estimate sits 1.1-fold (0.03 log units) below what was measured; measured number inside the range.
By their numbers in this assay, from the lowest: compound 3; then compounds 4 and 1 (each within the scatter of the next); then compound 2.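

Among these compounds, the exchange of hydroxymethyl for carboxy is the only step here that alters the hydroxymethyl itself, and in this assay it gives a 2.1-fold higher number from compound 3 to compound 4 (0.32 log units; beyond the scatter), so this group does register in the read-out, though modestly. The 1-carboxy-2-methylpropyl group also gives a 2.8-fold lower number from compound 2 to compound 4 (0.45 log units; beyond the scatter) and a 1.1-fold lower number from compound 1 to compound 4 (0.05 log units; within the scatter), which keeps compound 4 apart from compound 2 but leaves it unresolved from compound 1. No measurement available here accounts for these shifts.

The compounds shown leave open whether the step follows the carbonyl or the free carboxylic acid, which a methyl ester or a primary carboxamide on the same saturated chain carbon would separate. Also open, going by these compounds, is whether the exchange reads the same on another framework, as a 1-carboxy-1-methylethyl group would show.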